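Aryl ether variation on the pyridine of the shared core

The source may hold more compounds than are shown below. What is called first, only, known or untested is meant among the compounds shown, and "the series" means these compounds.

compound 1 `COc1cncc(C2=CC3CNCC(C2)C3)c1`: 14.3 nM
compound 2 `C1=C(c2cncc(OCc3ccccc3)c2)CC2CNCC1C2`: 44 nM

Both numbers come from an in vitro assay on SH-SY5Y cells for displacement of a labelled ligand from Neuronal acetylcholine receptor; alpha3/beta4 (Homo sapiens); on this read-out lower numbers stand for stronger inhibition and higher numbers for weaker inhibition. Compound 2 stands highest of the two numbers measured; its nearest neighbour is compound 1, and the step of a 3.1-fold higher number from compound 1 to compound 2 (0.49 log units; beyond the scatter) is modest but beyond the scatter.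

Compound 3 `C1=C(c2cncc(Oc3ccccc3)c2)CC2CNCC1C2` is not yet measured. It differs from compound 2 by phenyl in place of benzyl on an oxygen on an aromatic ring. Among the measured compounds shown here, only one measured step bears on this change, and only indirectly: a 3.1-fold higher number from compound 1 to compound 2 (0.49 log units; beyond the scatter) covers phenyl in place of hydrogen on a saturated chain carbon bound to an oxygen on an aromatic ring, which is the opposite direction of growth from the change now made. Compound 3 keeps one six-membered aromatic ring of carbon only on the oxygen, as compound 2 does, so a step of comparable size back toward compound 1 is at most what is expected, and a result within the scatter of compound 2 would not surprise. The step of a 1.5-fold lower number from compound 2 to compound 3 (0.17 log units; within the scatter) is therefore expected to be small. Compound 3 is estimated at 30 nM in this assay, with a range of 10 nM to 100 nM.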

Compound 3, inhibition constant: 1.9 nM
Compound 3: the middle estimate sits 16-fold (1.20 log units) above what was measured, outside the stated range (below it).
By their numbers in this assay, from the lowest: compound 3; then compound 1; then compound 2.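

Notes on the group on the oxygen on an aromatic ring: in this assay the result depends on more than the presence of the aromatic ring, since benzyl and phenyl each carry one six-membered aromatic ring of carbon only, yet phenyl in place of benzyl gives a 23-fold lower number from compound 2 to compound 3 (1.36 log units; beyond the scatter) and is a large step. Measured against methyl, the two ring-bearing groups fall on opposite sides, with a 3.1-fold higher number from compound 1 to compound 2 (0.49 log units; beyond the scatter) for benzyl and a 7.5-fold lower number from compound 1 to compound 3 (0.88 log units; beyond the scatter) for phenyl, so the numbers in these three compounds do not follow the heavy-atom count of the group, and compound 3 now stands lowest with both of its steps beyond the scatter. The data shown offer nothing that accounts for the gap between benzyl and phenyl.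

The compounds shown leave open whether the low number of compound 3 survives substitution on the phenyl ring, for instance by fluoro or methoxy, or replacement of that ring by a pyridine ring. Also open, as far as these compounds go, is how a longer chain such as 2-phenylethyl on the oxygen would read, and whether an amine nitrogen or a sulfur in place of the oxygen would hold the number.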